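A few compounds are considered here, and "the series" means these few. Any claim that something is new, unique, unknown or untested is made for them only; others in the source may bear on it.

Measured compounds:
- compound 1, `CCCC(=O)C1=C(C)NC(=O)NC1c1ccsc1`: 9%
- compound 2, `CC1=C(C(=O)SC(C)C)C(c2ccsc2)NC(=O)N1`: 14%
- compound 3, `CCC(CC)OC(=O)C1=C(C)NC(=O)NC1c1ccsc1`: 26%

All three were tested in an assay on membranes from HEK293 cells for displacement of a labelled ligand from adenosine receptor A2b (Homo sapiens), read by scintillation counting, with a stated time of 30 min, tested at 1 uM; on this read-out higher numbers stand for more inhibition at the one concentration tested (going by the name of the read-out) and lower numbers for less inhibition. Compound 3 stands highest of the three: the step of a number 17 percentage points higher from compound 1 to compound 3 (beyond the scatter) and the step of a number 12 percentage points higher from compound 2 to compound 3 (beyond the scatter) both lie beyond the scatter, while the step of a number 5 percentage points higher from compound 1 to compound 2 (within the scatter) does not. Compound 4, `CC1=C(C(=O)OC2CCCCC2)C(c2ccsc2)NC(=O)N1`, has not yet been measured. It differs from compound 3 in one place: cyclohexyl in place of pentan-3-yl on an oxygen next to a carbonyl group. For the measured compounds named here, none of the measured steps alters the group on that oxygen; they change what sits on the carbonyl carbon itself. Going by the values given here, the expectation for compound 4 therefore rests on compound 3 alone, because its value of 26% is the only measurement with a group on that oxygen. Since the change keeps a carbon-only group of similar size and no new donors or acceptors enter, the expected step of a number 2 percentage points higher from compound 3 to compound 4 (within the scatter) is small, within the scatter, in no firm direction. Compound 4 is estimated at 28%, with a range from 12% to 44%.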

Compound 4, a percentage reported as inhibition, at one concentration (the size of the read-out at that concentration, not a potency): 4%
Beside the measured number, compound 4's estimate is 24 percentage points above it; the measured number lies below the stated range.
By their numbers in this assay, from the lowest: compounds 4, 1 and 2 (each within the scatter of the next); then compound 3.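

For the compounds shown here, this is the only change here made on the oxygen rather than on the carbonyl carbon, and in this assay replacing the open-chain pentan-3-yl with the ring of cyclohexyl gives a number 22 percentage points lower from compound 3 to compound 4 (beyond the scatter) even though both groups are carbon only. The oxygen link alone therefore does not secure the number seen for compound 3: with cyclohexyloxy on the carbonyl carbon, the steps of a number 10 percentage points lower from compound 2 to compound 4 (within the scatter) and a number 5 percentage points lower from compound 1 to compound 4 (within the scatter) leave compound 4 level with the propyl and isopropylsulfanyl compounds. Nothing available gives a reason for this drop.

Only these two groups on the oxygen can be compared, a narrow basis for any rule about that position. Going by these compounds, whether an isopropyl, a cyclopentyl or a longer chain such as hexyl would follow pentan-3-yl or cyclohexyl remains open.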